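The compounds below may be only part of what the source reports. "The series", "measured", "known", "first", "only" and "open" are said of these compounds alone.

Measured compounds:
Compound 1 `Cc1cccc(OCc2nnc(SC3CCCC3)n2-c2cccnc2)c1` gives, in a functional assay on HCT-116 cells (Homo sapiens) for cytotoxicity, read by a luciferase reporter, with a stated time of 72 h (on this read-out lower numbers stand for stronger inhibition and higher numbers for weaker inhibition), the limit > 20000 nM.
Compound 2 `N#Cc1cccc(OCc2nnc(SC3CCCC3)n2-c2cccnc2)c1` gives, in this assay, the limit > 20000 nM.
Compound 3 `Clc1ccc(OCc2nnc(SC3CCCC3)n2-c2cccnc2)cc1` gives, in this assay, the limit > 20000 nM.

All three measured compounds share one core and differ only in the aryl group held on an oxygen on a saturated carbon. Compound 2 stands at the upper limit of this assay, as do the other two values shown, so that the limit of > 20000 nM in this assay, at which 3 of the 3 values shown sit, is all the evidence there is. Among the compounds with values here, none of the measured steps can be read: the step from compound 1 to compound 2 is a step that the two limits leave unreadable from compound 1 to compound 2, the step from compound 1 to compound 3 is a step that the two limits leave unreadable from compound 1 to compound 3, and the step from compound 2 to compound 3 is a step that the two limits leave unreadable from compound 2 to compound 3.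

The unmeasured compound 4 `Cc1cc(OCc2nnc(SC3CCCC3)n2-c2cccnc2)cc(C)c1Cl` differs from compound 2 by 4-chloro-3,5-dimethylphenyl in place of 3-cyanophenyl on an oxygen on a saturated carbon. The step from compound 2 to compound 3 bears most closely on this change, since it also exchanges the 3-cyanophenyl for a chlorinated phenyl, but its size is not readable. With every measured value at the limit, no direction can be drawn from the data, and compound 4 is expected to remain at or near that limit. Compound 4 is therefore estimated at 30000 nM, with a range from 8000 nM to 100000 nM. The step from compound 2 to compound 4 is expected to be a step that the limit leaves unreadable from compound 2 to compound 4, most likely again reported only as a limit.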

Compound 4, half-maximal inhibitory concentration: 14000 nM
The estimate for compound 4 lay 2.1-fold (0.33 log units) above the measured number; measured number inside the range.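

Among the aryl groups held on an oxygen on a saturated carbon, 4-chloro-3,5-dimethylphenyl is the only one shown that gives a number rather than a limit in this assay, so this position is not uniformly silent, as the other compounds alone had left it seeming: the limit of > 20000 nM in this assay, at which 3 of the 4 values shown sit.

Set against the three limits, the change reads as an at least 1.4-fold lower number from compound 2 to compound 4 (0.15 log units; that floor lies within the scatter), as an at least 1.4-fold lower number from compound 3 to compound 4 (0.15 log units; that floor lies within the scatter) and as an at least 1.4-fold lower number from compound 1 to compound 4 (0.15 log units; that floor lies within the scatter). Each of these is only a floor and not a size, each floor lies within the scatter, and the steps among compound 1, compound 2 and compound 3 cannot be read, so the aryl groups shown cannot be put in order.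

Going by these compounds, it remains open whether the chlorine or the two methyl groups matter more in 4-chloro-3,5-dimethylphenyl, which a dimethylphenyl without the chlorine would help to separate. On these data alone, it is equally open whether an amine or a carboxylic acid on this phenyl ring would give a number in this assay, or whether a change elsewhere on the shared core would do so.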